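A few compounds are considered here, and "the series" means these few. Any claim that something is new, unique, unknown or untested is made for them only; others in the source may bear on it.

In a functional assay on cells (Platelet, Homo sapiens) for inhibition (on this read-out higher numbers stand for weaker inhibition and lower numbers for stronger inhibition), compound 1 (`CCCOC(=O)c1ccc(-c2nn(Cc3ccccc3)c3ccccc23)cc1`) gives > 10000 nM as a limit of the assay, not a number. Compound 2 (`NC(=O)c1ccc(-c2nn(Cc3ccccc3)c3ccccc23)cc1`) gives > 10000 nM and this too is only a limit. Within the data shown here, both compounds thus sit at one shared limit (the limit of > 10000 nM in this assay, at which 2 of the 2 values shown sit) and the one measured step (a step that the two limits leave unreadable from compound 1 to compound 2) has no readable size. Compound 3 (`CNC(=O)c1ccc(-c2nn(Cc3ccccc3)c3ccccc23)cc1`) differs from compound 2 by methyl in place of hydrogen on an amide-type nitrogen with methyl in place of hydrogen on an amide-type nitrogen. Among the measured compounds shown here, no measured step gives a size to carry over, so no shift beyond the scatter is expected in this assay and no direction can be favoured. The estimated a number no higher from compound 2 to compound 3 (the limit leaves the size open) is accordingly small. For compound 3 the expected value is 10000 nM with an estimated range from 3000 nM to 30000 nM and a report at the limit is likely.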

Compound 3, half-maximal inhibitory concentration: > 10000 nM
Compound 3 gave a limit, no number; the forecaster's own chance of this, stated with the estimate: 75%; the middle value sits exactly at the limit.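

Compound 3 also gives only a limit, so no step among compound 1, compound 2 and compound 3 can be read: the limit of > 10000 nM in this assay, at which 3 of the 3 values shown sit.

The compounds shown leave open how strongly any of them inhibits in this assay, and whether the changes on the carbonyl carbon make any difference there.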